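Epimer at a ring carbon: expected half-life of compound 3

The compounds below may be only part of what the source reports. "The series", "measured", "known", "first", "only" and "open" are said of these compounds alone.

Two measured compounds share one core. Compound 1 `CC1(C)[C@H](C(=O)OCc2ccc(C(=O)O)cc2)N2C(=O)[C@H](NC(=O)C(F)(F)F)[C@@H]2[S+]1[O-]` carries an ester link to the benzoic acid arm; in a physicochemical assay (on this read-out lower numbers stand for a shorter-lived compound and higher numbers for a longer-lived compound), compound 1 gives 5.3 h. Compound 2 `CN(Cc1ccc(C(=O)O)cc1)C(=O)[C@@H]1N2C(=O)[C@H](NC(=O)C(F)(F)F)[C@@H]2[S+]([O-])C1(C)C` carries a methylated amide link to the same arm, and in this assay compound 2 gives 8.6 h. The two numbers lie within the usual scatter of each other, so no order between them is claimed. Among the measured compounds shown here, no pair of measured compounds differs in one place only, so no single-change step is available.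

Compound 3 `CN(Cc1ccc(C(=O)O)cc1)C(=O)[C@@H]1N2C(=O)[C@H](NC(=O)C(F)(F)F)[C@H]2[S+]([O-])C1(C)C` differs from compound 2 only in configuration: the two compounds have the same atoms and bonds; at least one stereo element is drawn with a configuration in one of them and without one in the other: 1 of 4 stereo elements differ; a stereocentre at a saturated ring carbon is drawn S in compound 2 and R in compound 3. For the measured compounds named here, no measured pair shows what inverting this centre does in this assay. With atoms and bonds unchanged, the step is expected to be small, a 1.2-fold lower number from compound 2 to compound 3 (0.09 log units; within the scatter), with no clear direction and not beyond the scatter. Compound 3 is estimated at 7 h in this assay, with a range from 3 h to 16 h that leaves room for the inversion mattering more than the two measured compounds can show.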

Compound 3, half-life: 8.2 h
Estimate against measurement, compound 3: 1.2-fold (0.07 log units) below; the measured number falls inside the stated range.
By their numbers in this assay, from the lowest: compounds 1, 3 and 2 (each within the scatter of the next).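

Inverting the stereocentre at the saturated ring carbon gives, in this assay, a 1.0-fold lower number from compound 2 to compound 3 (0.02 log units; within the scatter). Among the compounds shown here, this is the first single-change step, and it shows that with the methylated amide link in place, this change at this position leaves the half-life within the scatter. One caution applies to reading the step as a clean inversion: the fact that one of compounds 2 and 3 is drawn with a defined configuration and the other without, at the place where they differ

Open, on these data alone, is whether the same inversion stays as flat with the ester link of compound 1, or with a secondary amide link that lacks the methyl group. Also open, as far as these compounds go, is whether a plain acetyl group in place of the trifluoroacetyl group, or a sulfone in place of the sulfoxide, would change what this stereocentre does in this assay.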